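A few compounds are considered here, and "the series" means these few. Any claim that something is new, unique, unknown or untested is made for them only; others in the source may bear on it.

Measured compounds in a physicochemical assay for solubility, read by spectrophotometry, in phosphate buffer, with a stated time of 2 h, at pH 7.4; a lower number here means a less soluble compound, a higher number a more soluble compound:
Compound 1 `COc1ccc2[nH]c(C(=O)N3CC(=O)N(Cc4ccccc4)[C@@H](CN4CCCC4)C3)cc2c1` gives > 25000 nM, which is a limit of the assay rather than a number.
Compound 2 `COc1ccc2[nH]c(C(=O)N3CC(=O)N(Cc4cccc(OC(F)F)c4)[C@@H](CN4CCC(C#N)CC4)C3)cc2c1` gives 27900 nM.
Compound 3 `COc1ccc2[nH]c(C(=O)N3CC(=O)N(Cc4cccc(OC(F)F)c4)[C@@H](CN4CCCCC4)C3)cc2c1` gives 26400 nM.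

Compound 1 therefore stands at the limit (the limit of > 25000 nM in this assay, at which 1 of the 3 values shown sits), and the two compounds with numbers sit close to that same region. Among the measured compounds shown here, the only measured step, a 1.1-fold lower number from compound 2 to compound 3 (0.02 log units; within the scatter), concerns a different part of the molecule and does not bear on the change considered here.

Compound 4 `COc1ccc2[nH]c(C(=O)N3CC(=O)N(Cc4ccccc4)[C@@H](CN4CCn5cccc5C4)C3)cc2c1` differs from compound 1 by a group of 9 heavy atoms (7 carbon, 2 nitrogen; one five-membered aromatic ring with 1 hetero atom, one six-membered non-aromatic ring with 2 hetero atoms) in place of a group of 5 heavy atoms (4 carbon, 1 nitrogen; one five-membered non-aromatic ring with 1 hetero atom), on a saturated chain carbon bound to a saturated ring carbon. For the measured compounds named here, no measured step covers this change, so the expectation rests on the narrow spread of the values seen. The expected step is an at least 1.2-fold lower number from compound 1 to compound 4 (0.09 log units; that floor lies within the scatter), within the scatter. Compound 4 is estimated at 20000 nM, ranging from 8000 nM to 30000 nM.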

Compound 4, solubility: 29700 nM
Estimate against measurement, compound 4: 1.5-fold (0.17 log units) below; low and high end bracket the measured number.
By their numbers in this assay, from the lowest: compounds 3, 2 and 4 (each within the scatter of the next).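

The step from compound 1 to compound 4 cannot be read, because the result for compound 1 is a limit of the assay and not a number: the limit of > 25000 nM in this assay, at which 1 of the 4 values shown sits.

The compounds shown leave open how far, if at all, replacing the pyrrolidin-1-yl group with the group in compound 4 shifts the number in this assay.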